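Swapping the amine on a coumarin-bearing pyrazoline amide

A few compounds are considered here, and "the series" means these few. Any claim that something is new, unique, unknown or untested is made for them only; others in the source may bear on it.

Compound 3 `O=C(CNC1CC1)N1N=C(c2cc3ccccc3oc2=O)CC1c1ccccc1`: 28500 nM
Compound 1 `CC1=NN(S(=O)(=O)c2ccc(C)cc2)C(c2cc(Br)ccc2O)C1`: 33200 nM
Compound 2 `CC1=NN(C(=O)CN2CCC(c3ccccc3)CC2)C(c2ccccc2O)C1`: 20400 nM

Of the compounds shown here, three have been measured in a functional assay on PC-3 cells (Homo sapiens) for cytotoxicity, read by MTT assay, with a stated time of 48 h; on this read-out lower numbers stand for stronger inhibition and higher numbers for weaker inhibition. Compound 3 gives 28500 nM. Its number stands second highest of the three, but the gap to compound 1 and the gap to compound 2 both lie within the scatter of repeated measurements, so the three compounds cannot be told apart on these data. Within the data shown here, none of them differs from another in a single place, so no step between measured compounds is available to guide expectations.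

Compound 4 `O=C(CN1CCC(O)CC1)N1N=C(c2cc3ccccc3oc2=O)CC1c1ccccc1` has not yet been measured. It differs from compound 3 in one place: 4-hydroxypiperidin-1-yl in place of cyclopropylamino on a saturated chain carbon bound to a carbonyl carbon. Among the measured compounds shown here, with no comparable step among the measured compounds, and the measured values all lying within the scatter of one another, there is no basis for expecting a shift in either direction. The step from compound 3 to compound 4 is therefore expected to be a 1.1-fold lower number from compound 3 to compound 4 (0.04 log units; within the scatter), not beyond the scatter. Compound 4 is estimated at 26000 nM, with a range from 9000 nM to 75000 nM.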

Compound 4, half-maximal inhibitory concentration: "not active" (no number reported)
Compound 4 has no reported number here, and the estimate cannot be compared.
By their numbers in this assay, from the lowest: compounds 2, 3 and 1 (each within the scatter of the next).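

In this assay, among these compounds, compound 4 is reported as not active, without a number, and no step from compound 3 to compound 4 can be read. The compounds shown leave open how far 4-hydroxypiperidin-1-yl in place of cyclopropylamino moves the number. Nothing measured here accounts for this result.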